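The source may report more compounds than this note shows. Statements on the series, on what has been measured and on what is new or still open speak of the compounds shown alone.

Among the compounds with values here, compound 1 `CCCCOC(=O)Nc1ccc([Se]C#N)cc1` is one of two compounds measured in a functional assay on CCRF-CEM cells (Homo sapiens) for cytotoxicity, read by MTT assay, with a stated time of 72 h; a lower number here means that less compound is tolerated, a higher number that more compound is tolerated. In this assay compound 1 gives 63500 nM, and compound 2 `O=C(Nc1ccc([Se][Se]c2ccc(NC(=O)Oc3ccccc3)cc2)cc1)Oc1ccccc1`, a diselenide carrying two phenyl carbamates, gives 73700 nM; the two values lie within the scatter of each other, so nothing separates compound 1 from compound 2 on these numbers. Compound 3 `N#C[Se]c1ccc(NC(=O)Oc2ccccc2)cc1` has not yet been measured in this assay. It differs from compound 1 in one place: phenyl in place of butyl on an oxygen next to a carbonyl group. Within the data shown here, no measured pair shows this change alone, and the only phenyl carbamate measured, compound 2, differs from compound 1 in more than this one place. Compound 3 is therefore expected to stay close to compound 1, with a step of a 1.2-fold lower number from compound 1 to compound 3 (0.06 log units; within the scatter) that does not go beyond the scatter. For compound 3 the estimate in this assay is 55000 nM, in a range from 20000 nM to 150000 nM.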

Compound 3, concentration lethal to 50% of the cells: 73200 nM
Beside the measured number, compound 3's estimate is 1.3-fold (0.12 log units) below it, and the stated range covers the measured number.
By their numbers in this assay, from the lowest: compounds 1, 3 and 2 (each within the scatter of the next).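

In this assay the exchange of phenyl for butyl on an oxygen next to a carbonyl group now has a measured pair of its own, which shows a 1.2-fold higher number from compound 1 to compound 3 (0.06 log units; within the scatter). The earlier compounds shown here could not show this, since compound 2 differs from compound 1 in more than one place. At this position, then, one six-membered aromatic ring can stand in place of the butyl chain without the number leaving the scatter, and no measurement at hand offers an explanation for this result.

Going by these compounds, it remains open whether a longer chain, a benzyl group or a chain ending in an amine or a carboxylic acid on this oxygen would separate from compound 1. The two compounds in this pair also leave open what a change elsewhere in the shared core would do.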